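The source may hold more compounds than are shown below. What is called first, only, known or untested is meant among the compounds shown, and "the series" means these compounds.

Measured in an ADME assay on HFF cells (Homo sapiens) for cytotoxicity, with a stated time of 8 days; on this read-out higher numbers stand for lower toxicity in this test and lower numbers for higher toxicity in this test:
- Compound 1 `CCCSc1nc(N)nc2c1ncn2/C=C1/CC1(CO)CO`: > 300000 nM, a limit
- Compound 2 `CCCOc1nc(N)nc2c1ncn2/C=C1/CC1(CO)CO`: > 300000 nM, a limit

Compound 2 has no number to its name, only the limit > 300000 nM. Among the compounds with values here, it shares that position with compound 1, and the whole series so far stands at the limit of > 300000 nM in this assay, at which 2 of the 2 values shown sit.

Compound 3 `Nc1nc(SC2CCCC2)c2ncn(/C=C3/CC3(CO)CO)c2n1` changes one place on the shared core: cyclopentylsulfanyl in place of propoxy on an aromatic carbon. The new group sits on an aromatic carbon, next to the ring nitrogen, where compound 2 carries propoxy.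

Within the data shown here, only one measured step bears on this change, a step that the two limits leave unreadable from compound 1 to compound 2. It exchanged propylsulfanyl for propoxy at the same place and gives no size to carry over. Compound 1 does show that a sulfur-linked chain at this place can still reach the limit > 300000 nM. Among the measured compounds shown here, no measured compound carries the five-membered ring, so some uncertainty remains, and any readable shift is expected to run towards lower numbers, meaning higher toxicity in this test.

The expected change is an at least 1.5-fold lower number from compound 2 to compound 3 (0.17 log units; that floor lies within the scatter), which is small. For compound 3 the estimate is 200000 nM, with an expected range from 60000 nM to 300000 nM.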

Compound 3, half-maximal cytotoxic concentration: > 300000 nM
Compound 3: only a limit was reported; the forecaster's own chance of this, stated with the estimate: 65%; at least 1.5-fold (0.17 log units) between middle value and limit.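

Within the data shown here, compound 3 also ends at a limit, and no step among compound 1, compound 2 and compound 3 can be read: the limit of > 300000 nM in this assay, at which 3 of the 3 values shown sit. The compounds shown leave open how far beyond that limit each one lies, and whether any group at this place on the shared core would give a readable number in this assay.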